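Three hydroxyphenyl-bearing compounds measured, a fourth pending

A few compounds are considered here, and "the series" means these few. Any claim that something is new, unique, unknown or untested is made for them only; others in the source may bear on it.

Measured in an assay on isolated protein for inhibition of DNA topoisomerase 1 (Homo sapiens), with a stated time of 30 min, tested at 100 uM; on this read-out higher numbers stand for more inhibition at the one concentration tested (going by the name of the read-out) and lower numbers for less inhibition:
compound 1 `Oc1ccc(-c2cc(-c3cccc(O)c3)cc(-c3cccc(O)c3)n2)cc1` — 0%
compound 2 `Oc1cccc(-c2cc(-c3cccc(O)c3)nc(-c3cccc(O)c3)c2)c1` — 0%
compound 3 `Oc1ccc(-c2cc(-c3ccccc3O)cc(-c3ccccc3O)n2)cc1` — 0.3%

Compound 1 and compound 2 share a core and differ by 3-hydroxyphenyl in place of 4-hydroxyphenyl on an aromatic carbon; the step is no change at the digits printed from compound 1 to compound 2 (within the scatter). Compound 3 differs from compound 1 in a way that is not broken down here, since the two cores differ in more than one place. In this assay compound 3 gives 0.3%, a number within the scatter of both compound 1 and compound 2, so no order among the three can be drawn.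

Compound 4 `Oc1cccc(-c2cc(-c3ccccc3O)cc(-c3ccccc3O)n2)c1` is not yet measured. It differs from compound 3 by 3-hydroxyphenyl in place of 4-hydroxyphenyl on an aromatic carbon. This is the same kind of change as that from compound 1 to compound 2, though the surroundings differ: in the earlier pair the place is meta to two 3-hydroxyphenyl groups, here it is meta to two 2-hydroxyphenyl groups.

For compound 4 the step is expected to be a number 0.2 percentage points higher from compound 3 to compound 4 (within the scatter), because no change at the digits printed from compound 1 to compound 2 (within the scatter) showed no change on the same kind of move and compound 3 already gives 0.3%. Compound 4 is therefore estimated at 0.5%, expected between 0% and 6%.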

Compound 4, a percentage reported as inhibition, at one concentration (the size of the read-out at that concentration, not a potency): 0%
Estimate against measurement, compound 4: 0.5 percentage points above; the range from low to high includes it.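

In this assay, 3-hydroxyphenyl in place of 4-hydroxyphenyl gives a number 0.3 percentage points lower from compound 3 to compound 4 (within the scatter). Set beside the earlier pair, the change carries from one core to the other with no difference that can be told apart: the same change on two cores in this assay, no change at the digits printed (within the scatter) from compound 1 to compound 2 and a number 0.3 percentage points lower (within the scatter) from compound 3 to compound 4, 0.3 percentage points apart, within the scatter of two such steps

This does not show that the position of the hydroxyl on this ring is of no consequence in general, since all four compounds give numbers close to the bottom of the read-out at the one concentration tested, and agreement there says little about how the change would carry over on a core with real inhibition.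

The compounds shown carry only hydroxyphenyl groups, so it stays open whether an amine, a carboxylic acid or a longer chain in place of one of them would give a number clearly above the others. Also open, as far as these compounds go, is how these compounds would read at another concentration, and whether this change would give a step beyond the scatter on a core with a clearly higher number.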